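Aryl sulfonamide variation on a shared core

The source may hold more compounds than are shown below. What is called first, only, known or untested is meant among the compounds shown, and "the series" means these compounds.

Three analogues share one core and differ only in the aryl group on the sulfonyl sulfur. In an assay on MDA-MB-231 cells for binding affinity to C-X-C chemokine receptor type 4 (Homo sapiens), read by microscopy, with stated times of 10 min and 30 min (on this read-out lower numbers stand for an effect already at smaller amounts and higher numbers for an effect only at larger amounts of compound), compound 1 `O=C(NCc1ccc(CNS(=O)(=O)c2ccc([N+](=O)[O-])cc2)cc1)c1ccc(CNc2ncccn2)cc1` gives 1000 nM. Compound 2 `O=C(NCc1ccc(CNS(=O)(=O)c2ccc3c(c2)CCO3)cc1)c1ccc(CNc2ncccn2)cc1` gives 1000 nM, and compound 3 `O=C(NCc1ccc(CNS(=O)(=O)c2ccccc2F)cc1)c1ccc(CNc2ncccn2)cc1` gives 1000 nM. Compound 3 thus stands level with compound 1 and compound 2 on these numbers; nothing separates the three.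

Compound 4 `O=C(NCc1ccc(CNS(=O)(=O)c2cccc3ccccc23)cc1)c1ccc(CNc2ncccn2)cc1` continues the same variation: naphthalen-1-yl in place of 2-fluorophenyl on a sulfonyl sulfur. The measured steps bear on it directly, since each also exchanges the aryl group on the sulfonyl sulfur, and no change at the digits printed from compound 1 to compound 2 (within the scatter), no change at the digits printed from compound 1 to compound 3 (within the scatter) and no change at the digits printed from compound 2 to compound 3 (within the scatter) all stay within the scatter. For the measured compounds named here, no measured step brings in naphthalen-1-yl, so the expectation rests on the flatness seen so far rather than on a direct precedent. The step from compound 3 to compound 4 is expected to be no change at the digits printed from compound 3 to compound 4 (within the scatter), that is, nothing beyond the scatter. Compound 4 is therefore estimated at 1000 nM, with a range of 400 nM to 2500 nM.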

Compound 4, effective concentration (reported as EC, without a stated level of effect): 1000 nM
Compound 4: the middle estimate sits on the measured number at the digits printed, within the range that was stated.
By their numbers in this assay, from the lowest: compounds 1, 2, 3 and 4 (each within the scatter of the next).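

In this assay, for the compounds shown here, the flat picture now reaches the only group of the four with 2 six-membered aromatic rings of carbon only: naphthalen-1-yl in place of 2-fluorophenyl gives no change at the digits printed from compound 3 to compound 4 (within the scatter). The comparisons with the other two aryl groups read the same, with no change at the digits printed from compound 2 to compound 4 (within the scatter) and no change at the digits printed from compound 1 to compound 4 (within the scatter), so on this sulfonyl sulfur a group of 10 carbon atoms stands level with groups carrying fluorine, oxygen or nitrogen. No supporting data offer an explanation for this flatness.

On these data alone, all four compounds keep an aryl group on the sulfonyl sulfur, so it remains open whether a cyclohexyl or methyl group there, or an aryl ring bearing an amine or a carboxylic acid, would read beyond the scatter. The shared core is also constant throughout, so these compounds cannot show how the sulfonyl aryl group behaves on any other core.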